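Methoxy removal from compound 3 to compound 4

The compounds below may be only part of what the source reports. "The series", "measured", "known", "first", "only" and "open" are said of these compounds alone.

Measured so far in an assay on HeLa cells for displacement of a labelled ligand from adenosine receptor A3 (Homo sapiens), read by scintillation counting, with a stated time of 180 min, tested at 10 uM; on this read-out lower numbers stand for less inhibition and higher numbers for more inhibition at the one concentration tested (going by the name of the read-out):
- compound 1 `N=c1oc2ccc(Br)cc2cc1C(=O)NCC(O)CO` gives 10%
- compound 2 `N=c1oc2ccc(Br)cc2cc1C(=O)NCCO` gives 0%
- compound 3 `COc1cc(Br)cc2cc(C(=O)NCCCO)c(=N)oc12` gives 23%

Compound 3 stands highest of the three numbers, beyond the scatter above both compound 1 and compound 2. Going by the values given here, the one single-point step measured so far runs along the amide chain: a number 10 percentage points lower from compound 1 to compound 2 (within the scatter). It says nothing about the aromatic ring.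

Compound 4 `N=c1oc2ccc(Br)cc2cc1C(=O)NCCCO` is compound 3 with the methoxy taken off: hydrogen in place of methoxy on an aromatic carbon. Among the compounds with values here, no measured pair differs at that ring position, so there is no step to lean on. Compound 3 shares its chain with compound 4 and differs from compound 1 and compound 2 both in the chain and in the methoxy, so the gap between compound 3 and those two cannot be split between the two changes.

Within the data shown here, with no precedent, the expectation is a modest drop from compound 3, estimated as a number 10 percentage points lower from compound 3 to compound 4 (within the scatter), with wide uncertainty spanning the unsubstituted analogues. Compound 4 is expected to give 13% in this assay, in the range 0% to 30%.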

Compound 4, a percentage reported as inhibition, at one concentration (the size of the read-out at that concentration, not a potency): 17%
Estimate against measurement, compound 4: 4 percentage points below; the range from low to high includes it.
By their numbers in this assay, from the lowest: compounds 2, 1, 4 and 3 (each within the scatter of the next, the first and the last beyond it).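

In this assay, going by these compounds alone, hydrogen in place of methoxy on the aromatic carbon ortho to a fused ring gives a number 6 percentage points lower from compound 3 to compound 4 (within the scatter) and is the first reading at this position, so the methoxy and the hydrogen cannot be told apart here. Within the data shown here, the same compound also links the chain variations in single changes, which the earlier compounds could not do apart from the one step between compound 1 and compound 2: hydroxymethyl in place of hydroxy on a saturated chain carbon gives a number 17 percentage points higher from compound 2 to compound 4 (beyond the scatter) as the one modest step at the chain, while hydrogen in place of hydroxy on a saturated chain carbon gives a number 7 percentage points higher from compound 1 to compound 4 (within the scatter) and cannot be told apart from no change. Nothing available here accounts for either the ring result or the chain results.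

The compounds shown leave open whether an amine or a carboxylic acid in place of the terminal hydroxy, or a longer chain, would go beyond this modest step, and whether ethoxy or chloro on the same aromatic carbon would separate from methoxy and hydrogen. As far as these compounds go, each number also remains the size of the read-out at a single concentration, so the potency of the series stays open.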